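Dihalophenyl ketones: forecast for compound 4

A few compounds are considered here, and "the series" means these few. Any claim that something is new, unique, unknown or untested is made for them only; others in the source may bear on it.

Compound 1 `COc1ccc(-c2cc(/C=C/C(=O)c3ccc(OC)c(OC)c3)[nH]n2)cc1`: 94%
Compound 2 `COc1cc(-c2cc(/C=C/C(=O)c3ccc(Cl)c(Cl)c3)[nH]n2)cc(OC)c1OC`: 68%
Compound 3 `COc1ccc(C(=O)/C=C/c2cc(-c3cc(OC)c(OC)c(OC)c3)n[nH]2)cc1`: 87%

In a functional assay on HOP-62 cells (Homo sapiens) for cytotoxicity, read by sulforhodamine B assay, with a stated time of 48 h, tested at 1 uM (a lower number here means a stronger effect, a higher number a weaker effect of the compound at the concentration tested), compound 3 stands second highest of the three numbers; compound 1 lies within the scatter of it, and compound 2 lies beyond the scatter below it. Compound 4 `COc1cc(-c2cc(/C=C/C(=O)c3ccc(F)c(F)c3)[nH]n2)cc(OC)c1OC` differs from compound 3 by 3,4-difluorophenyl in place of 4-methoxyphenyl on a carbonyl carbon. For the measured compounds named here, one measured step bears on this: a number 19 percentage points higher from compound 2 to compound 3 (beyond the scatter), where 4-methoxyphenyl replaced 3,4-dichlorophenyl. Going by the values given here, the present change runs the opposite way, 3,4-difluorophenyl for 4-methoxyphenyl, so a lowering step in this assay is expected, though fluorine has no direct precedent in this set and the size is uncertain. Compound 4 is therefore expected to give 75%, between 60% and 90%. The expected step is a number 12 percentage points lower from compound 3 to compound 4 (beyond the scatter).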

Compound 4, a percentage reported as activity, at one concentration (the size of the read-out at that concentration, not a potency): 94%
Beside the measured number, compound 4's estimate is 19 percentage points below it; the measured number lies above the stated range.
By their numbers in this assay, from the lowest: compound 2; then compounds 3, 1 and 4 (each within the scatter of the next).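

With a number 7 percentage points higher from compound 3 to compound 4 (within the scatter) in this assay, 3,4-difluorophenyl and 4-methoxyphenyl on the carbonyl carbon cannot be told apart. With a number 26 percentage points higher from compound 2 to compound 4 (beyond the scatter), the two halogens separate at this position, so the pair of compounds 2 and 4 shows that a dihalophenyl ketone does not by itself give the lower number of compound 2. Nothing available explains this difference.

Left open is whether the change follows chlorine itself or its number on the ring. 4-Chlorophenyl or 3,4-dibromophenyl on the carbonyl carbon would bear on this, and a morpholine amine there would test whether an aryl group is needed at all.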